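The source may hold more compounds than are shown below. What is called first, only, known or untested is meant among the compounds shown, and "the series" means these compounds.

Of the compounds shown here, three built on one shared core have been measured in a functional assay on SAOS-2 cells (Homo sapiens) for antiproliferative activity, read by MTT assay, with a stated time of 72 h; a higher number here means a weaker inhibitor, a lower number a stronger inhibitor. Compound 1 `CCOc1ccc(NC2=C(C(=O)c3ccccc3)C(c3ccc(Br)cc3)N(CCCn3ccnc3)C2=O)cc1` gives 30900 nM. Compound 2 `O=C(C1=C(Nc2ccc(I)cc2)C(=O)N(CCCn2ccnc2)C1c1ccc(Br)cc1)c1ccccc1`, carrying iodo in place of ethoxy on an aromatic carbon, gives 23400 nM. Compound 3 `O=C(C1=C(Nc2ccc(Cl)cc2)C(=O)N(CCCn2ccnc2)C1c1ccc(Br)cc1)c1ccccc1`, carrying chloro at that carbon instead, gives 24800 nM. The three numbers lie close together: a 1.3-fold lower number from compound 1 to compound 2 (0.12 log units; within the scatter), a 1.2-fold lower number from compound 1 to compound 3 (0.10 log units; within the scatter) and a 1.1-fold higher number from compound 2 to compound 3 (0.03 log units; within the scatter) are each within the scatter, so compound 3 cannot be told apart from either of the other two in this assay.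

Compound 4 `O=C(C1=C(Nc2ccccc2Br)C(=O)N(CCCn2ccnc2)C1c1ccc(Br)cc1)c1ccccc1` differs from compound 3 by 2-bromophenyl in place of 4-chlorophenyl on an amine nitrogen. Among the compounds with values here, the only measured step that bears on this is the exchange of one halogen for another on that ring, where a 1.1-fold higher number from compound 2 to compound 3 (0.03 log units; within the scatter) stayed within the scatter. The change from a 4-chlorophenyl to a 2-bromophenyl itself has no measured counterpart among these compounds. The expectation is therefore a step of a 1.0-fold higher number from compound 3 to compound 4 (0.00 log units; within the scatter) in this assay, nothing beyond the scatter. Compound 4 is expected to give 25000 nM in this assay, between 11000 nM and 55000 nM.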

Compound 4, half-maximal inhibitory concentration: 19600 nM
The estimate for compound 4 lay 1.3-fold (0.11 log units) above the measured number, within the range that was stated.
By their numbers in this assay, from the lowest: compounds 4, 2, 3 and 1 (each within the scatter of the next).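

In this assay, the exchange on the amine nitrogen gives a 1.3-fold lower number from compound 3 to compound 4 (0.10 log units; within the scatter) and the comparisons with the other two compounds give a 1.2-fold lower number from compound 2 to compound 4 (0.08 log units; within the scatter) and a 1.6-fold lower number from compound 1 to compound 4 (0.20 log units; within the scatter) as well. The earlier compounds shown here all carried their group at the 4 place of the ring, so this first 2-bromophenyl shows that a change in both the halogen and its place on the ring leaves all steps within the scatter. No measurement here offers an explanation for how close these numbers lie.

The halogen and its place changed together, so a 2-chlorophenyl or a 4-bromophenyl would be needed to separate the two. From the compounds shown here alone, whether an amine or a carboxylic acid on this ring would give a step beyond the scatter also remains open.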